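Working notes: cyano for hydroxymethyl in compound 4

The compounds below may be only part of what the source reports. "The series", "measured", "known", "first", "only" and "open" are said of these compounds alone.

Measured so far in a functional assay on the whole organism (strain Wistar albino) for inhibition, with Rattus norvegicus as the target, read by paw edema, with a stated time of 3 h, at a dose of 100 mg/kg by the oral route; on this read-out higher numbers stand for more inhibition at the one dose given (going by the name of the read-out) and lower numbers for less inhibition:
compound 1 `Cc1ccc2c(Cc3nn4cc(-c5ccc(Cl)cc5)nc4s3)coc2c1` gives 51.7%
compound 2 `Cc1ccc2c(Cc3nn4c(CO)c(-c5ccc(Cl)cc5)nc4s3)coc2c1` gives 45.9%
compound 3 `Cc1ccc2c(Cc3nn4c(CO)c(-c5ccc(Br)cc5)nc4s3)coc2c1` gives 36.7%

Compound 2 stands second highest of the three numbers. Its nearest neighbour is compound 1, with a number 5.8 percentage points lower from compound 1 to compound 2 (within the scatter), and its furthest is compound 3, with a number 9.2 percentage points lower from compound 2 to compound 3 (within the scatter); both steps are within the scatter, so no order among the three can be read from these numbers.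

The next compound, compound 4 `Cc1ccc2c(Cc3nn4c(C#N)c(-c5ccc(Cl)cc5)nc4s3)coc2c1`, differs from compound 2 by cyano in place of hydroxymethyl on an aromatic carbon. Among the measured compounds shown here, of the two measured steps, only the one from compound 1 to compound 2 touches the same aromatic carbon, the hydroxymethyl entering in place of hydrogen there, and it stayed within the scatter with a number 5.8 percentage points lower from compound 1 to compound 2 (within the scatter). The step from compound 2 to compound 3 concerns the halogen on the 4-chlorophenyl group and bears only indirectly; it too was within the scatter. For the measured compounds named here, nothing measured here distinguishes a cyano from a hydroxymethyl at this position, and the one change made at it moved the read-out by less than the scatter. A step in this assay no larger than the scatter, in either direction, is therefore expected.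

For compound 4 the estimated value is 47%, with a range from 35% to 59%. The expected step is a number 1.1 percentage points higher from compound 2 to compound 4 (within the scatter).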

Compound 4, a percentage reported as inhibition, in the whole organism at one dose (the size of the read-out at that dose, not a potency): 43.4%
The estimate for compound 4 lay 3.6 percentage points above the measured number; the range from low to high includes it.
By their numbers in this assay, from the lowest: compounds 3, 4, 2 and 1 (each within the scatter of the next, the first and the last beyond it).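

In this assay cyano in place of hydroxymethyl on this aromatic carbon gives a number 2.5 percentage points lower from compound 2 to compound 4 (within the scatter) and cyano in place of hydrogen gives a number 8.3 percentage points lower from compound 1 to compound 4 (within the scatter) so neither step separates the groups compared at this carbon. This carbon now carries two different substituents, and hydrogen and both groups remain indistinguishable on this read-out at the one dose given. Hydroxymethyl has 1 hydrogen-bond donor and cyano has 0 hydrogen-bond donors, so a hydrogen-bond donor on this carbon is not shown to be required for the read-out in these compounds, and no supporting data explain the result.

Still open, on these data alone, is whether an aminomethyl group, a carboxylic acid or a longer chain such as hydroxyethyl on this carbon would give a step beyond the scatter. Also open, as far as these compounds go, is whether cyano would give a similar result with the 4-bromophenyl group of compound 3 in place of the 4-chlorophenyl group, and whether the closeness seen at this single dose and time would hold at other doses or times.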